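Swapping Phenyl for Methylthiophene on a Shared Amide Core

The compounds below may be only part of what the source reports. "The series", "measured", "known", "first", "only" and "open" are said of these compounds alone.

Measured compounds:
compound 1, `CCOc1cc(NC(=O)CCCCCC(=O)Nc2cc(-c3ccccc3)ccc2N)cc2c1OCC([N+](=O)[O-])=C2`: 4860 nM
compound 2, `CCOc1cc(NC(=O)CCCCCCC(=O)Nc2cc(-c3ccccc3)ccc2N)cc2c1OCC([N+](=O)[O-])=C2`: 5400 nM
compound 3, `CCOc1cc(NC(=O)CCCCCCC(=O)Nc2cc(-c3ccc(C)s3)ccc2N)cc2c1OCC([N+](=O)[O-])=C2`: 5830 nM

Three compounds were measured in a functional assay on A549 cells (Homo sapiens) for antiproliferative activity, read by MTT assay, with a stated time of 48 h; on this read-out lower numbers stand for stronger inhibition of growth and higher numbers for weaker inhibition of growth. Compound 1 and compound 2 differ in their cores; the difference between the two cores is not broken down here. Their values lie within the scatter of each other, so nothing is said about their order. Compound 3 differs from compound 2 in one place: 5-methylthiophen-2-yl in place of phenyl on an aromatic carbon. This change gave a 1.1-fold higher number from compound 2 to compound 3 (0.03 log units; within the scatter), so the number stayed essentially where it was.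

Compound 4, `CCOc1cc(NC(=O)CCCCCC(=O)Nc2cc(-c3ccc(C)s3)ccc2N)cc2c1OCC([N+](=O)[O-])=C2`, has not yet been measured. It differs from compound 1 by 5-methylthiophen-2-yl in place of phenyl on an aromatic carbon, the same change, at the same place, as that from compound 2 to compound 3. Because that earlier step was a 1.1-fold higher number from compound 2 to compound 3 (0.03 log units; within the scatter), the step from compound 1 to compound 4 is expected to be of the same small size, namely a 1.1-fold higher number from compound 1 to compound 4 (0.04 log units; within the scatter). Compound 4 is therefore estimated at 5300 nM in this assay, with a likely range from 2700 nM to 10500 nM.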

Compound 4, concentration for 50% growth inhibition: 5070 nM
Compound 4: middle estimate off by 1.0-fold (0.02 log units), on the high side; the range from low to high includes it.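

In this assay, putting 5-methylthiophen-2-yl in place of phenyl on the core of compound 1 gave a 1.0-fold higher number from compound 1 to compound 4 (0.02 log units; within the scatter), so the number stayed essentially where it was. Set beside the earlier step, the same change behaved alike on the two cores: the same change on two cores in this assay, a 1.1-fold higher number (0.03 log units; within the scatter) from compound 2 to compound 3 and a 1.0-fold higher number (0.02 log units; within the scatter) from compound 1 to compound 4, 1.0-fold (0.01 log units) apart, within the scatter of two such steps. This shows that in these two pairs the swap left the number essentially unmoved on either core, but it does not show that the same would hold on any other core or in any other test, and it gives no reason why the number hardly moved.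

The compounds shown leave open what an amine, a carboxylic acid or a simple methyl at that place would do to the number, and whether a longer chain joining the two amides would shift it. From the compounds shown here alone, all four compounds also carry the same nitro and ethoxy groups, so what removing either group would do remains unknown.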